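Cytotoxicity notes: ring-nitrogen substituents on the shared core

The source may hold more compounds than are shown below. What is called first, only, known or untested is meant among the compounds shown, and "the series" means these compounds.

The series keeps one core and varies the group on the amide-type nitrogen in the ring. Compound 1 `CS(=O)(=O)Nc1ccc2c(c1)S(=O)(=O)N=C(C1=C(O)C3CCCC3N(Cc3ccccn3)C1=O)N2` carries pyridin-2-yl on a saturated chain carbon bound to that nitrogen. In an ADME assay on Huh-7 cells (Homo sapiens) for cytotoxicity, with a stated time of 72 h (on this read-out higher numbers stand for lower toxicity in this test and lower numbers for higher toxicity in this test), compound 1 gives > 33000 nM, which is a limit of the assay and not a number. Compound 2 `CS(=O)(=O)Nc1ccc2c(c1)S(=O)(=O)N=C(C1=C(O)C3CCCC3N(Cc3ccc(Cl)cc3)C1=O)N2` carries 4-chlorophenyl on the same chain carbon. In this assay compound 2 gives > 10000 nM, again a limit rather than a number. The step that the two limits leave unreadable from compound 1 to compound 2 therefore cannot be read; the two bounds the limit of > 10000 nM in this assay, at which 1 of the 3 values shown sits, and the limit of > 33000 nM in this assay, at which 1 of the 3 values shown sits, are all that is known of toxicity in this set.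

Compound 3 `CS(=O)(=O)Nc1ccc2c(c1)S(=O)(=O)N=C(C1=C(O)C3CCCC3N(c3ccccc3)C1=O)N2` carries phenyl directly on the ring nitrogen. In this assay compound 3 gives "not determined" (no result reported). Compound 3 thus has no number of its own; the two further values in the set are both limits.

Compound 4 `CS(=O)(=O)Nc1ccc2c(c1)S(=O)(=O)N=C(C1=C(O)C3CCCC3N(CCC3CC3)C1=O)N2` differs from compound 3 by 2-cyclopropylethyl in place of phenyl on an amide-type nitrogen in a ring.

Going by the values given here, no measured step bears on this change, since the only pair that differs in one place is unreadable. Both measured compounds sit at assay limits, so for compound 4 the expectation in this assay is a value at or beyond the limit, with no step size predicted beyond the scatter. Compound 4 is estimated at 30000 nM, within 10000 nM to 100000 nM.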

Compound 4, half-maximal cytotoxic concentration: > 33000 nM
Compound 4 was reported as a limit; the forecaster's own chance of this, stated with the estimate: 80%; middle value at least 1.1-fold (0.04 log units) away from the limit.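

In this assay compound 4 gives > 33000 nM, a limit and not a number. Going by these compounds alone, the steps to compound 4 from compound 1 and from compound 2 therefore cannot be read, so this result adds no new step. The compounds shown leave open at what concentration any of these ring-nitrogen substituents becomes cytotoxic in this assay.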